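A Chloro Substituent on the Aryl Ring of Compound 2

This account rests on a few compounds, and the source may have more. Where it says the series, first, only, none or still open, it means among the compounds named here.

Two compounds have been characterised in an assay on Expi293F cells for binding affinity to adenosine receptor A3 (Homo sapiens), read by surface plasmon resonance; a lower number here means tighter binding, a higher number weaker binding. Compound 1 `CS(=O)(=O)c1ccc(C(=O)Nc2cccc(Cl)c2)cc1` gives 18000 nM. Compound 2 `Nc1nsc(-c2ccccc2)n1`, built on a different core, gives 102000 nM, the higher of the two numbers; the gap to compound 1 lies beyond the usual scatter, so compound 2 is the weaker binder of the pair. The next compound keeps the core of compound 2. Compound 3 `Nc1nsc(-c2ccc(Cl)cc2)n1` differs from compound 2 by chloro in place of hydrogen on an aromatic carbon, a chloro in place of hydrogen on an aromatic carbon. Within the data shown here, no measured pair in this set isolates such a change, so the size of the step rests on expectation alone. The step from compound 2 to compound 3 is expected to be a moderate drop in the number, estimated as a 2.6-fold lower number from compound 2 to compound 3 (0.41 log units; beyond the scatter). Compound 3 is therefore expected to give about 40000 nM in this assay, within a range of 10000 nM to 150000 nM.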

Compound 3, dissociation constant: 36500 nM
Compound 3: the middle estimate sits 1.1-fold (0.04 log units) above what was measured; measured number inside the range.
By their numbers in this assay, from the lowest: compound 1; then compound 3; then compound 2.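

On the core of compound 2, a chloro in place of hydrogen on an aromatic carbon, para to a group of 6 heavy atoms, gives a 2.8-fold lower number from compound 2 to compound 3 (0.45 log units; beyond the scatter) in this assay. Among these compounds, this is the only pair in the set that isolates a single change, and it shows that this position of the six-membered aromatic ring responds measurably, though modestly, to one added chlorine atom. Nothing available accounts for the size of this step.

The compounds shown leave open whether a fluoro, a methoxy or an amine on the same carbon would shift the number as far, and whether a chloro on another carbon of that ring would do the same. They also leave open how the number would respond if a methyl replaced the amine on the shared core.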